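A pyridine ring in place of the iodophenyl amide

The source may hold more compounds than are shown below. What is called first, only, known or untested is meant among the compounds shown, and "the series" means these compounds.

Three amides sharing one core have been tested in a functional assay on HEK293 cells for agonist activity at probable G-protein coupled receptor 27 (Homo sapiens), read by a luciferase reporter and beta-arrestin recruitment, with a stated time of 10 min; a higher number here means a larger maximal response, a lower number a smaller maximal response. Compound 1 `O=C(Nc1ccc(S(=O)(=O)Nc2ccccc2)cc1)c1cc(F)c(Cl)cc1F` gives 37%, compound 2 `Cc1cc(Cl)ccc1C(=O)Nc1ccc(S(=O)(=O)Nc2ccccc2)cc1` gives 123%, and compound 3 `O=C(Nc1ccc(S(=O)(=O)Nc2ccccc2)cc1)c1ccc(I)cc1F` gives 36%. Compound 3 has the lowest of the three numbers, though its gap to compound 1 is small: a number 1 percentage points lower from compound 1 to compound 3 (within the scatter). The gap to compound 2 is large: a number 87 percentage points lower from compound 2 to compound 3 (beyond the scatter).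

Compound 4 `O=C(Nc1ccc(S(=O)(=O)Nc2ccccc2)cc1)c1ccc(Cl)nc1F` is the next compound. 6-chloro-2-fluoropyridin-3-yl in place of 2-fluoro-4-iodophenyl on a carbonyl carbon

Two of the steps bear on this change. The step of a number 1 percentage points lower from compound 1 to compound 3 (within the scatter) shows that swapping one ring carrying fluorine and a second halogen for another such ring leaves the maximal response in this assay where it was. The step of a number 87 percentage points lower from compound 2 to compound 3 (beyond the scatter) shows that a ring carrying a methyl and a chlorine behaves very differently, but compound 4 has no methyl. For the measured compounds named here, the ring entering compound 4 still carries a fluorine and a chlorine, and the data hold no example of a nitrogen-containing ring at this position, so the expected step is small. For compound 4 the estimate in this assay is 42%, with a range from 20% to 80%, which means an expected step of a number 6 percentage points higher from compound 3 to compound 4 (within the scatter).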

Compound 4, largest response reached (Emax), in percent of the reference or control that the assay uses: 78%
Beside the measured number, compound 4's estimate is 36 percentage points below it, within the range that was stated.
By their numbers in this assay, from the lowest: compounds 3 and 1 (each within the scatter of the next); then compound 4; then compound 2.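

In this assay, the step of a number 42 percentage points higher from compound 3 to compound 4 (beyond the scatter) and the step of a number 41 percentage points higher from compound 1 to compound 4 (beyond the scatter) show that a ring carrying fluorine and a second halogen does not by itself fix the maximal response at this place on the carbonyl carbon. Compounds 1 and 3 had suggested that it might, but 6-chloro-2-fluoropyridin-3-yl also carries fluorine and a halogen and reaches a clearly different level, although the step of a number 45 percentage points lower from compound 2 to compound 4 (beyond the scatter) leaves compound 2 with the highest number of the four. Going from compound 3 to compound 4 replaces a ring carbon with nitrogen and iodine with chlorine in a single change, and no measurement available here explains the rise.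

The compounds shown therefore leave open how much of the rise belongs to the ring nitrogen and how much to the change of halogen, which a phenyl ring carrying the same fluorine and chlorine could help to separate. They also leave open whether a methyl on the pyridine ring would raise the response further, and how an amine or a carboxylic acid on that ring would behave.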